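From Cyclopropyl to Cyclohexyl on a Fused Core

A few compounds are considered here, and "the series" means these few. Any claim that something is new, unique, unknown or untested is made for them only; others in the source may bear on it.

Compound 1 `O=C(O)c1cccc(Cc2c(-c3cccc(Cl)c3)nn3cc(Cl)ccc23)n1` — 480 nM
Compound 2 `COc1ccc(-c2nn3cc(Cl)ccc3c2Cc2cccc(C(=O)O)n2)cc1` — 5400 nM
Compound 3 `O=C(O)c1cccc(Cc2c(C3CC3)nn3cc(Cl)ccc23)n1` — 1500 nM

Three compounds share a core and differ only in the group on an aromatic carbon. In a functional assay on cells for antagonist activity at prostaglandin E2 receptor EP1 subtype (Rattus norvegicus), read by fluorescence and calcium flux, with a stated time of 60 s (on this read-out lower numbers stand for stronger inhibition and higher numbers for weaker inhibition), compound 1 gives 480 nM, compound 2 gives 5400 nM and compound 3 gives 1500 nM. Compound 3 therefore stands second highest of the three, with compound 1 as its nearest neighbour and compound 2 furthest away: a 3.1-fold higher number from compound 1 to compound 3 (0.49 log units; beyond the scatter) and a 3.6-fold lower number from compound 2 to compound 3 (0.56 log units; beyond the scatter).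

Compound 4 `O=C(O)c1cccc(Cc2c(C3CCCCC3)nn3cc(Cl)ccc23)n1` is not yet measured. The change cyclohexyl in place of cyclopropyl on an aromatic carbon keeps a non-aromatic carbon ring but enlarges it. Going by the values given here, no measured step swaps one such ring for another; the only steps touching this position exchange an aromatic ring for cyclopropyl, and they go in opposite directions, one modest loss (a 3.1-fold higher number from compound 1 to compound 3 (0.49 log units; beyond the scatter)) and one modest gain (a 3.6-fold lower number from compound 2 to compound 3 (0.56 log units; beyond the scatter)). The shown data thus give no direct guide to ring size here. For compound 4 the expected step is a 1.7-fold lower number from compound 3 to compound 4 (0.22 log units; within the scatter), of modest size at most in this assay. Compound 4 is estimated at 900 nM, within 300 nM to 3000 nM.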

Compound 4, half-maximal inhibitory concentration: 1200 nM
Compound 4: middle estimate off by 1.3-fold (0.12 log units), on the low side, and the stated range covers the measured number.
By their numbers in this assay, from the lowest: compound 1; then compounds 4 and 3 (each within the scatter of the next); then compound 2.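

In this assay, going by these compounds alone, the first exchange of one non-aromatic carbon ring for another at this position gives (a 1.3-fold lower number from compound 3 to compound 4 (0.10 log units; within the scatter)), so on this read-out the six-membered ring of cyclohexyl cannot be told apart from the three-membered ring of cyclopropyl. Cyclohexyl also repeats the opposite steps seen for cyclopropyl against the two aromatic groups, with (a 4.5-fold lower number from compound 2 to compound 4 (0.65 log units; beyond the scatter)) on one side and (a 2.5-fold higher number from compound 1 to compound 4 (0.40 log units; beyond the scatter)) on the other, which places both carbon rings on the same footing relative to 4-methoxyphenyl and 3-chlorophenyl. No measurement shown here explains why ring size matters so little at this position.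

Only two ring sizes are shown, so cyclobutyl and cyclopentyl remain open. So does whether an open chain such as n-butyl, or a ring holding nitrogen such as piperidinyl, would behave like these carbon rings.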